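Swapping a naphthyl for a thiophenyl on a shared core

This account rests on a few compounds, and the source may have more. Where it says the series, first, only, none or still open, it means among the compounds named here.

The series shares one core, varied only in the aryl group attached to it. Compound 1 `c1ccc(-c2cn3ccnc3c(-c3ccc4ncn(C5CCCCC5)c4c3)n2)cc1` gives 1.74 in a physicochemical assay for lipophilicity, using the shake flask method, in phosphate buffer, measured as octanol-water partition, with a stated time of 85 min, at pH 7.4; a lower number here means a more polar compound, a higher number a more lipophilic compound. Among the measured compounds shown here, compound 2 `c1ccc2c(-c3cn4ccnc4c(-c4ccc5ncn(C6CCCCC6)c5c4)n3)cccc2c1` gives 1.44 in this assay; this is the lowest of the two numbers so far, though the step of a number 0.30 log units lower from compound 1 to compound 2 (within the scatter) is within the scatter, so the two compounds are not distinguishable on these numbers. Compound 3 `c1cn2cc(-c3ccsc3)nc(-c3ccc4ncn(C5CCCCC5)c4c3)c2n1` is not yet measured. Relative to compound 2 it carries thiophen-3-yl in place of naphthalen-1-yl on an aromatic carbon. For the measured compounds named here, only one measured step bears on this change, a number 0.30 log units lower from compound 1 to compound 2 (within the scatter), which also exchanges the aryl group at this place and stayed within the scatter. With such a small reference step, no change beyond the scatter is expected in this assay, and compound 3 is estimated at 1.55, within 1.15 to 1.95, an expected step of a number 0.11 log units higher from compound 2 to compound 3 (within the scatter).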

Compound 3, partition coefficient: 1.81
The estimate for compound 3 lay 0.26 log units below the measured number; the measured number falls inside the stated range.
By their numbers in this assay, from the lowest: compounds 2, 1 and 3 (each within the scatter of the next, the first and the last beyond it).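

In this assay, among the compounds shown here, replacing naphthalen-1-yl with thiophen-3-yl on this aromatic carbon gives the first step at this position that lies beyond the scatter (a number 0.37 log units higher from compound 2 to compound 3 (beyond the scatter)). Replacing phenyl with the same group gives no distinguishable change (a number 0.07 log units higher from compound 1 to compound 3 (within the scatter)), so compound 1 cannot be separated from either of the others, and only compound 2 and compound 3 can be told apart. No measurement shown here accounts for the modest step between those two compounds.

The compounds shown leave open whether an amine or a carboxylic acid on this aromatic carbon would move the number further than these aromatic rings do. On these data alone, it also remains open whether the separation of compound 2 holds for other two-ring groups, since naphthalen-1-yl is the only one here.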